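A few compounds are considered here, and "the series" means these few. Any claim that something is new, unique, unknown or untested is made for them only; others in the source may bear on it.

In a functional assay on A2780 cells (Homo sapiens) for cytotoxicity, read by sulforhodamine B assay, with a stated time of 72 h (a higher number here means a weaker inhibitor, a lower number a stronger inhibitor), compound 1 `O=C(NCc1ccc(S(=O)(=O)c2cc(F)cc(F)c2)cc1)N1Cc2ccncc2C1` gives 6.3 nM and compound 2 `O=C(NCc1ccc(S(=O)(=O)N2CCC[C@@H](O)C2)cc1)N1Cc2ccncc2C1` gives 70 nM, which makes compound 2 the higher number of the two, and so the weaker inhibitor. Within the data shown here, the only measured step, an 11-fold higher number from compound 1 to compound 2 (1.05 log units; beyond the scatter), puts 3-hydroxypiperidin-1-yl in place of 3,5-difluorophenyl on a sulfonyl sulfur, and it is large. Compound 3 `O=C(NCc1ccc(S(=O)(=O)N2CCC[C@H](O)C2)cc1)N1Cc2ccncc2C1` is a much smaller change from compound 2: the two compounds have the same atoms and bonds and differ only in configuration as drawn: 1 of 1 stereo elements differ; a stereocentre at a saturated ring carbon is drawn R in compound 2 and S in compound 3. A stereocentre at a saturated ring carbon is drawn R in compound 2 and S in compound 3, while nothing leaves and nothing enters. Among the measured compounds shown here, the large step swapped a whole group, so it bears only loosely here, and no measured pair differs in configuration alone. No direction can be favoured, and the expected step, no change at the digits printed from compound 2 to compound 3 (within the scatter), stays within the scatter. Compound 3 is estimated at 70 nM, with an expected range of 25 nM to 200 nM.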

Compound 3, half-maximal inhibitory concentration: 150 nM
Compound 3: middle estimate off by 2.1-fold (0.33 log units), on the low side, within the range that was stated.
By their numbers in this assay, from the lowest: compound 1; then compound 2; then compound 3.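

Inverting the stereocentre at a saturated ring carbon gives, in this assay, a 2.1-fold higher number from compound 2 to compound 3 (0.33 log units; beyond the scatter), so this small change is modest but still detectable, and the R form as drawn gives the lower number. This shift can be assigned to the stereocentre alone because nothing else separates the pair: the fact that compounds 2 and 3 differ only in the configuration as drawn

Even so, the configuration matters less here than the group on the sulfonyl sulfur, since 3-hydroxypiperidin-1-yl in place of 3,5-difluorophenyl gives a 24-fold higher number from compound 1 to compound 3 (1.38 log units; beyond the scatter) with the S form as well.

The compounds shown leave open how a plain piperidin-1-yl without the hydroxyl, or a ring carrying an amine or a methoxy group instead, would compare with compound 2 and compound 3. They also leave open whether the order of these two compounds would hold in other cell lines.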